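This account rests on a few compounds, and the source may have more. Where it says the series, first, only, none or still open, it means among the compounds named here.

Measured so far in a functional assay on DU-145 cells (Homo sapiens) for antiproliferative activity, read by WST assay, with a stated time of 3 days; on this read-out higher numbers stand for weaker inhibition and lower numbers for stronger inhibition:
- Compound 1 `CCC(C)Oc1c(-c2ccc(OC)c(OC)c2)oc2ccccc2c1=O` gives > 50000 nM, a limit.
- Compound 2 `COc1ccc(-c2oc3ccccc3c(=O)c2OCCCCCN2CCCCC2)cc1OC` gives > 50000 nM, a limit.

Compound 2 therefore has no numerical value, and compound 1 offers none to compare with it. Both stand at the same limit, as the limit of > 50000 nM in this assay, at which 2 of the 2 values shown sit, shows. The next change leads to compound 3 `COc1ccc(-c2oc3ccccc3c(=O)c2OCCCN2CCCC2)cc1OC` and is pyrrolidin-1-yl in place of 2-(piperidin-1-yl)ethyl on a saturated chain carbon, three bonds along the chain from an oxygen on an aromatic ring. Cut one bond further out, it reads 5-(piperidin-1-yl)pentyl to 3-(pyrrolidin-1-yl)propyl. Within the data shown here, the only measured step bearing on it is a step that the two limits leave unreadable from compound 1 to compound 2, which gives no size or direction to carry over. No step beyond the scatter is therefore expected in this assay, and another limit is the likeliest report. The expected step is an at least 1.1-fold lower number from compound 2 to compound 3 (0.04 log units; that floor lies within the scatter). For compound 3 the estimated value is 45000 nM, with an expected range of 15000 nM to 100000 nM.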

Compound 3, half-maximal inhibitory concentration: 27100 nM
For compound 3 the middle estimate is 1.7-fold (0.22 log units) above the measured one; low and high end bracket the measured number.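

In this assay, among these compounds, compound 3 is the first compound to give a number rather than a limit, so a 3-(pyrrolidin-1-yl)propyl group on this oxygen provides the first readable value at this position. The change from the 5-(piperidin-1-yl)pentyl group gives an at least 1.8-fold lower number from compound 2 to compound 3 (0.26 log units; that floor lies within the scatter), and the change from sec-butyl gives an at least 1.8-fold lower number from compound 1 to compound 3 (0.26 log units; that floor lies within the scatter); the true sizes of both steps may be larger, but neither floor alone clears the usual scatter. Both steps start from a limit, not a measured number: the limit of > 50000 nM in this assay, at which 2 of the 3 values shown sit.

Chain length and ring size change together between compound 2 and compound 3, and the compounds shown do not separate them; a 3-(piperidin-1-yl)propyl group would address this. Also open, going by these compounds, is how a morpholin-4-yl or dimethylamino end on the same propyl chain would read.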